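This account rests on a few compounds, and the source may have more. Where it says the series, first, only, none or still open, it means among the compounds named here.

Measured compounds:
Compound 1 `Cn1ncc(Cl)c1-c1cc(C(=O)N[C@@H]2CN[C@H](CCN3CCC(O)CC3)C[C@H]2c2ccc(Cl)c(Cl)c2)oc1Cl`; in a functional assay on OVCAR-8 cells (Homo sapiens) for antiproliferative activity (a lower number here means a stronger inhibitor, a higher number a weaker inhibitor), compound 1 gives 15900 nM.
Compound 2 `CC(=O)NCC[C@@H]1C[C@@H](c2ccc(F)c(F)c2)[C@H](NC(=O)c2cc(-c3c(Cl)cnn3C)c(Cl)o2)CN1`; in this assay compound 2 gives 880 nM.

For the measured compounds named here, compound 1 stands at the highest of the two numbers; compound 2 sits well beyond the scatter below it, though the two differ in more than one place, so no single step connects them. Compound 3 `Cn1ncc(Cl)c1-c1cc(C(=O)N[C@@H]2CN[C@H](CC(=O)NCCO)C[C@H]2c2ccc(Cl)c(Cl)c2)oc1Cl` is not yet measured. It differs from compound 1 in one place: (2-hydroxyethyl)carbamoyl in place of (4-hydroxypiperidin-1-yl)methyl on a saturated chain carbon bound to a saturated ring carbon. Compound 2 likewise carries an amide-bearing chain at that position and shows the lower number, so a step toward a lower number is expected from compound 1 to compound 3, moderate in size. The expected step is a 4.0-fold lower number from compound 1 to compound 3 (0.60 log units; beyond the scatter). Compound 3 is estimated at 4000 nM, with a range of 1000 nM to 16000 nM.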

Compound 3, half-maximal inhibitory concentration: 1450 nM
Beside the measured number, compound 3's estimate is 2.8-fold (0.44 log units) above it; the range from low to high includes it.
By their numbers in this assay, from the lowest: compounds 2 and 3 (each within the scatter of the next); then compound 1.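

In this assay, for the compounds shown here, (2-hydroxyethyl)carbamoyl in place of (4-hydroxypiperidin-1-yl)methyl on a saturated chain carbon bound to a saturated ring carbon brings an 11-fold lower number from compound 1 to compound 3 (1.04 log units; beyond the scatter), the first single-place reading at this position. With the rest of the structure unchanged, the number clearly responds to the group carried here. Nothing measured on hand accounts for the size of this step.

As far as these compounds go, the six-membered non-aromatic ring leaves and the carbonyl enters in the same step, and their separate shares remain open. From the compounds shown here alone, how a carboxylic acid or a longer chain ending in the same hydroxyl would read at this place also remains open.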